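From Methoxy to Isopropoxymethyl: Expected Efficacy of Compound 3

The compounds below may be only part of what the source reports. "The series", "measured", "known", "first", "only" and "open" are said of these compounds alone.

Measured compounds:
compound 1 `CO/N=C(\CCN1CCN(c2ccccn2)CC1)c1ccc(Cl)cc1`: 87%
compound 2 `CO/N=C(/c1ccc(Cl)cc1)C(CN1CCN(c2ccccn2)CC1)OC`: 83%

In a functional assay on HEK293 cells with D(4) dopamine receptor (Homo sapiens) as the target, read by FLIPR (on this read-out lower numbers stand for smaller maximal responses and higher numbers for larger maximal responses), compound 1 gives 87% and compound 2 gives 83%. For the measured compounds named here, the only measured step, a number 4 percentage points lower from compound 1 to compound 2 (within the scatter), puts compound 2 within the scatter of compound 1, so the two numbers cannot be told apart. Compound 3 `CO/N=C(/c1ccc(Cl)cc1)C(COC(C)C)CN1CCN(c2ccccn2)CC1` differs from compound 2 by isopropoxymethyl in place of methoxy on a saturated chain carbon bound to a carbon with a double bond to nitrogen and a saturated chain carbon. Going by the values given here, the one step that bears on this change is a number 4 percentage points lower from compound 1 to compound 2 (within the scatter), which altered the same saturated chain carbon without moving the number beyond the scatter. Nothing measured points to a shift in either direction for a larger group at that carbon, so no step beyond the scatter is expected. Compound 3 is therefore estimated to give 82%, in the range 65% to 96%, which means an expected step of a number 1 percentage points lower from compound 2 to compound 3 (within the scatter).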

Compound 3, largest response reached (reported as efficacy), in percent of the reference or control that the assay uses: 60%
For compound 3 the middle estimate is 22 percentage points above the measured one; the measured number lies below the stated range.
By their numbers in this assay, from the lowest: compound 3; then compounds 2 and 1 (each within the scatter of the next).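

The saturated chain carbon bound to a carbon with a double bond to nitrogen and a saturated chain carbon proves sensitive to what it carries: in this assay isopropoxymethyl in place of methoxy gives a number 23 percentage points lower from compound 2 to compound 3 (beyond the scatter) and so does what methoxy in place of hydrogen, with a number 4 percentage points lower from compound 1 to compound 2 (within the scatter) as its step, did not do. For the compounds shown here, measured against the hydrogen of the unbranched chain, isopropoxymethyl gives a number 27 percentage points lower from compound 1 to compound 3 (beyond the scatter) and thus marks the first clear change at this carbon, with 5 heavy atoms entering where methoxy has 2 and the hydrogen-bond donor and acceptor counts unchanged. No available data bear on why the number falls with this change.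
The compounds shown leave open whether the fall follows the added carbon atoms or the branched ether itself. A hydroxymethyl group, a plain propyl chain or an amine on the same carbon would help separate these readings.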